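The source may report more compounds than this note shows. Statements on the series, on what has been measured and on what is new or still open speak of the compounds shown alone.

Compound 3 `C[C@]1(CN2CCc3nc(N4CCC(F)(F)CC4)ccc3C2)Cn2cc([N+](=O)[O-])nc2O1` is one of three compounds whose tolerance by Vero cells was examined in an ADME assay on Vero cells (Chlorocebus sabaeus) for cytotoxicity, read by MTT assay, with a stated time of 72 h (a lower number here means that less compound is tolerated, a higher number that more compound is tolerated), and for compound 3 the record shows "not determined" (no result reported). It therefore has no number of its own to stand on. Compound 1 `C[C@]1(CN2CCc3nc(-c4ccc(F)cc4)oc3C2)Cn2cc([N+](=O)[O-])nc2O1` is the only one of the three that reports anything, and for compound 1 that report is a limit of the assay, > 32 ug/mL, as the line the limit of > 32 ug/mL in this assay, at which 1 of the 3 values shown sits, shows. Compound 2 `C[C@]1(CN2CCn3nc(-c4ccc(F)c(F)c4)nc3C2)Cn2cc([N+](=O)[O-])nc2O1` likewise shows "not determined" (no result reported). Compound 4 `C[C@]1(CN2CCc3nc(-c4cc(F)ccc4F)ccc3C2)Cn2cc([N+](=O)[O-])nc2O1` has not been measured; it differs from compound 3 by 2,5-difluorophenyl in place of 4,4-difluoropiperidin-1-yl on an aromatic carbon. Among the compounds with values here, with no measured step available, no direction can be read from the data, and no change beyond the scatter of this assay is assumed. Compound 4 is expected to give about 32 ug/mL, within the range 16 ug/mL to 64 ug/mL.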

Compound 4, half-maximal cytotoxic concentration: > 32 ug/mL
Compound 4: only a limit was reported (the forecaster's own chance of this, stated with the estimate: 60%); the middle value sits exactly at the limit.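

Compound 3 has no reported result and compound 4 reports only a limit, so no step can be read between them. The compounds shown leave open where the half-maximal cytotoxic concentrations of compound 1 and compound 4 actually lie: the limit of > 32 ug/mL in this assay, at which 2 of the 4 values shown sit.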